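Stacking Aromatic Methyl Changes on the Shared Core

The source may hold more compounds than are shown below. What is called first, only, known or untested is meant among the compounds shown, and "the series" means these compounds.

Compound 1 `COC(=O)[C@@]1(C)CCC=C2[C@@H]1CC[C@@H](C)[C@]2(C)Cc1c[nH]c2ccc(C)cc12` and compound 2 `COC(=O)[C@@]1(C)CCC=C2[C@@H]1CC[C@@H](C)[C@]2(C)Cc1c(C)[nH]c2ccccc12` share one core and differ only in where a methyl sits. In a functional assay on SW1573 cells (Homo sapiens) for inhibition, read by sulforhodamine B assay, with a stated time of 48 h (on this read-out lower numbers stand for stronger inhibition of growth and higher numbers for weaker inhibition of growth), compound 1 gives 15000 nM; in this assay compound 2 gives 14000 nM. The two numbers lie within the scatter of each other, so compound 2 is not separated from compound 1. Compound 3 `COC(=O)[C@@]1(C)CCC=C2[C@@H]1CC[C@@H](C)[C@]2(C)Cc1c(C)[nH]c2ccc(C)cc12` carries methyl in place of hydrogen on an aromatic carbon, combining the substitution patterns of compound 1 and compound 2. Going by the values given here, with no measured step in hand, no shift beyond the scatter is expected for compound 3, with a 1.2-fold lower number from compound 2 to compound 3 (0.07 log units; within the scatter) as the estimated step. Compound 3 is estimated at 12000 nM, within 5000 nM to 30000 nM.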

Compound 3, concentration for 50% growth inhibition: 18000 nM
Estimate against measurement, compound 3: 1.5-fold (0.18 log units) below; the range from low to high includes it.
By their numbers in this assay, from the lowest: compounds 2, 1 and 3 (each within the scatter of the next).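

In this assay, adding methyl in place of hydrogen on an aromatic carbon gives a 1.3-fold higher number from compound 2 to compound 3 (0.11 log units; within the scatter), and adding the other methyl gives a 1.2-fold higher number from compound 1 to compound 3 (0.08 log units; within the scatter). Carrying both methyl groups on the shared core therefore does not separate compound 3 from either compound with one methyl. Nothing at hand bears on a cause.

Open, from the compounds shown here alone, is whether a chlorine atom, a methoxy group or an amine at this aromatic carbon would move the number beyond the scatter. Also open, going by these compounds, is how a compound with hydrogen at both places would read, and whether a carboxylic acid in place of the methyl ester would change the number.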